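Bromo for chloro: a one-atom swap on a shared core

This account rests on a few compounds, and the source may have more. Where it says the series, first, only, none or still open, it means among the compounds named here.

Three compounds have been measured in a functional assay on KM12 cells (Homo sapiens) for inhibition, read by sulforhodamine B assay, with a stated time of 48 h, tested at 10 uM; on this read-out higher numbers stand for more inhibition at the one concentration tested (going by the name of the read-out) and lower numbers for less inhibition:

Compound 1, `O=Cc1ccc(-c2cn3ccnc3c(-c3ccc4ncn(C5CCCCC5)c4c3)n2)cc1`, gives 3.69%.
Compound 2, `Fc1ccc(-c2cn3ccnc3c(-c3ccc4ncn(C5CCCCC5)c4c3)n2)cc1`, gives 3.49%.
Compound 3, `Clc1ccc(-c2cn3ccnc3c(-c3ccc4ncn(C5CCCCC5)c4c3)n2)cc1`, gives 10.6%.

Compound 3 carries the largest of the three numbers, yet both steps leading to it stay within the scatter: a number 6.9 percentage points higher from compound 1 to compound 3 (within the scatter) and a number 7.1 percentage points higher from compound 2 to compound 3 (within the scatter). The step of a number 0.2 percentage points lower from compound 1 to compound 2 (within the scatter) is likewise within the scatter, so the three measured compounds cannot be ordered in this assay.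

Compound 4, `Brc1ccc(-c2cn3ccnc3c(-c3ccc4ncn(C5CCCCC5)c4c3)n2)cc1`, has not yet been measured. Its difference from compound 3 is bromo in place of chloro on an aromatic carbon. The step that bears most directly on it is the earlier halogen exchange at the same place, a number 7.1 percentage points higher from compound 2 to compound 3 (within the scatter), which stayed within the scatter; the exchange a number 6.9 percentage points higher from compound 1 to compound 3 (within the scatter) was of the same kind and also within the scatter. Neither gives grounds to expect a move beyond the scatter for a second halogen exchange, so the expected step is a number 0.6 percentage points lower from compound 3 to compound 4 (within the scatter).

Compound 4 is therefore estimated to give 10% in this assay, expected to lie between 0% and 25%.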

Compound 4, a percentage reported as inhibition, at one concentration (the size of the read-out at that concentration, not a potency): 23.3%
Compound 4: the middle estimate sits 13.3 percentage points below what was measured; measured number inside the range.
By their numbers in this assay, from the lowest: compounds 2, 1 and 3 (each within the scatter of the next); then compound 4.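

In this assay, among these compounds, the change from 4-chlorophenyl to 4-bromophenyl is the first at this aromatic carbon, para to a large group, to produce a step beyond the scatter (a number 12.7 percentage points higher from compound 3 to compound 4 (beyond the scatter)), although it leaves the counts of heavy atoms, hydrogen-bond donors and hydrogen-bond acceptors unchanged. Bromo also stands apart from the fluoro and formyl groups at the same place (a number 19.8 percentage points higher from compound 2 to compound 4 (beyond the scatter); a number 19.6 percentage points higher from compound 1 to compound 4 (beyond the scatter)), so compound 4 is the one compound here separated from all the others, while those others remain unordered among themselves and all three of these steps are modest. Nothing measured in this set accounts for the separation of bromo from the other groups.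

The compounds shown leave open whether iodo, an amine, a carboxylic acid or a longer alkyl chain at this carbon would stay with compound 4 or fall back among the other three compounds. They also leave open whether the step from chloro to bromo would recur if the cyclohexyl group on the shared core were replaced by another group.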